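Methoxyphenyl thioether replaces dichlorophenyl thioether

The compounds below may be only part of what the source reports. "The series", "measured", "known", "first", "only" and "open" are said of these compounds alone.

In a functional assay on HCT-116 cells (Homo sapiens) for inhibition, read by sulforhodamine B assay, with a stated time of 48 h (a lower number here means a stronger inhibitor of growth, a higher number a weaker inhibitor of growth), compound 2 `Nc1cc(N)c2nc(-c3ccccc3)c(Oc3ccc(F)cc3)nc2c1` gives 81300 nM and compound 3 `Nc1cc(N)c2nc(-c3ccccc3)c(Sc3ccc(Cl)c(Cl)c3)nc2c1` gives 47900 nM. Compound 1 `CCOC(=O)[C@H](CCC(=O)O)NC(=O)c1ccc(Sc2nc3cc(N)cc(N)c3nc2-c2ccccc2)cc1` reaches only a limit of the assay, recorded as < 100000 nM. Of the two numbers shown, compound 3 has the lowest, but the step of a 1.7-fold lower number from compound 2 to compound 3 (0.23 log units; within the scatter) lies within the scatter, so the two compounds cannot be told apart on these data. Compound 4 `COc1ccc(Sc2nc3cc(N)cc(N)c3nc2-c2ccccc2)cc1` differs from compound 3 in one place: 4-methoxyphenyl in place of 3,4-dichlorophenyl on a sulfur. No measured step exchanges one aryl group for another on the sulfur, and the single step shown, (3,4-dichlorophenyl)sulfanyl in place of 4-fluorophenoxy, stayed within the scatter; one of the three values sits at the limit of < 100000 nM in this assay, at which 1 of the 3 values shown sits, which leaves the upper range of this series poorly defined. The account therefore expects a small step, if any, most likely toward a higher number, a 1.5-fold higher number from compound 3 to compound 4 (0.16 log units; within the scatter). Compound 4 is estimated at 70000 nM in this assay, with a range from 30000 nM to 160000 nM.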

Compound 4, concentration for total growth inhibition: < 100000 nM
Compound 4: a limit, no number (the forecaster's own chance of this, stated with the estimate: 35%); the middle value does not contradict the limit.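

In this assay compound 4 gives < 100000 nM, a limit and not a number. The steps from compound 2 and from compound 3 to compound 4 therefore cannot be read. The compounds shown leave open how 4-methoxyphenyl compares with 3,4-dichlorophenyl on the sulfur, and the upper range remains poorly defined: the limit of < 100000 nM in this assay, at which 2 of the 4 values shown sit.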